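The source may hold more compounds than are shown below. What is called first, only, known or untested is meant among the compounds shown, and "the series" means these compounds.

Compound 1 `CC(c1cc2cc(-c3cnn(C)c3)cnc2cc1F)n1nnc2ncc(-c3ccc(C(N)=O)c(F)c3)nc21` gives 1 uL/min in an ADME assay on microsomes from liver (Rattus norvegicus) for metabolic stability, read by LC-MS, using NADPH, with stated times of 5 min and 30 min, tested at 1 uM (on this read-out lower numbers stand for slow clearance and higher numbers for fast clearance), the lowest of the three numbers measured. Among the measured compounds shown here, compound 2 `CNC(=O)c1ccc(-c2cnc3nnn(C(C)c4cc5cc(-c6cnn(C)c6)cnc5cc4F)c3n2)cc1F` gives 12 uL/min in this assay, and the single change from compound 1 produced a 12-fold higher number from compound 1 to compound 2 (1.08 log units; beyond the scatter). For the measured compounds named here, compound 3 `CC(c1c(F)cc2ncc(-c3cnn(C)c3)cc2c1F)n1nnc2ncc(-c3ccc(C(N)=O)c(F)c3)nc21` gives 12 uL/min in this assay; here the single change from compound 1 produced a 12-fold higher number from compound 1 to compound 3 (1.08 log units; beyond the scatter). Compound 3 therefore stands level with compound 2 at the digits printed, the two together at the top of the measured set, and well apart from compound 1.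

Compound 4 `CNC(=O)c1ccc(-c2cnc3nnn(C(C)c4c(F)cc5ncc(-c6cnn(C)c6)cc5c4F)c3n2)cc1F` has not yet been measured. It differs from compound 3 in one place: methyl in place of hydrogen on an amide-type nitrogen. Going by the values given here, the one measured step that bears directly on this change is a 12-fold higher number from compound 1 to compound 2 (1.08 log units; beyond the scatter), where the same methyl entered on the same amide-type nitrogen. Starting from compound 3, which already sits high, a further increase is expected, though perhaps not as large as that earlier step. Compound 4 is expected to give about 60 uL/min, with a range from 20 uL/min to 180 uL/min. This estimate corresponds to an expected 5.0-fold higher number from compound 3 to compound 4 (0.70 log units; beyond the scatter).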

Compound 4, intrinsic clearance in a liver preparation (reported as CLH), per the amount of preparation that the assay uses: 48 uL/min
Beside the measured number, compound 4's estimate is 1.3-fold (0.10 log units) above it; low and high end bracket the measured number.
By their numbers in this assay, from the lowest: compound 1; then compounds 2 and 3 (each within the scatter of the next); then compound 4.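

In this assay, methyl in place of hydrogen on the amide-type nitrogen still gives a step where the added fluoro is already present, a 4.0-fold higher number from compound 3 to compound 4 (0.60 log units; beyond the scatter), but this step is smaller than the one on the core of compound 1: the same change on two cores in this assay, a 12-fold higher number (1.08 log units; beyond the scatter) from compound 1 to compound 2 and a 4.0-fold higher number (0.60 log units; beyond the scatter) from compound 3 to compound 4, 3.0-fold (0.48 log units) apart, beyond the scatter of two such steps. Read the other way, the fluoro gives a 4.0-fold higher number from compound 2 to compound 4 (0.60 log units; beyond the scatter), and its step is likewise smaller once the methyl is present: the same change on two cores in this assay, a 12-fold higher number (1.08 log units; beyond the scatter) from compound 1 to compound 3 and a 4.0-fold higher number (0.60 log units; beyond the scatter) from compound 2 to compound 4, 3.0-fold (0.48 log units) apart, beyond the scatter of two such steps. The two changes are therefore not independent in these four compounds, since together they give less than their separate steps on compound 1 would add up to.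

The compounds leave open whether an ethyl group or a longer chain on this nitrogen would continue the rise seen with methyl. They also cannot tell why each step shrinks when the other change is present.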